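This account rests on a few compounds, and the source may have more. Where it says the series, first, only, none or still open, it means among the compounds named here.

Compound 1 `CCCc1nc(-c2cnc3ccc(-c4ccc(N)cc4)cc3c2)no1`: in a functional assay on RD cells (Homo sapiens) for inhibition, read by luminescence and ATP content, with a stated time of 72 h (on this read-out lower numbers stand for higher toxicity in this test and higher numbers for lower toxicity in this test), it is reported only as > 800 nM, a limit of the test.
Compound 2 `Nc1ccc(-c2ccc3ncc(-c4noc(C(F)(F)F)n4)cc3c2)cn1`: in this assay compound 2 is reported only as > 2500 nM, again a limit.

Compound 2 therefore stands at the limit given by the limit of > 2500 nM in this assay, at which 1 of the 2 values shown sits, so only a floor is known for it. Compound 1 sits at the limit given by the limit of > 800 nM in this assay, at which 1 of the 2 values shown sits. Compound 3 `Fc1ccc(-c2ccc3ncc(-c4noc(C(F)(F)F)n4)cc3c2)cc1` differs from compound 2 by 4-fluorophenyl in place of 6-aminopyridin-3-yl on an aromatic carbon. Among the measured compounds shown here, no step between two measured compounds is available here, so the expected step that the limit leaves unreadable from compound 2 to compound 3 rests on compound 2 alone and is expected to stay within the scatter, most likely with a limit reported once more. For compound 3 the estimate is 3000 nM, with a range from 1000 nM to 10000 nM.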

Compound 3, half-maximal cytotoxic concentration: > 7400 nM
Compound 3 ended at the assay's limit; the forecaster's own chance of this, stated with the estimate: 80%; middle value at least 2.4-fold (0.39 log units) from the limit.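

Compound 2 and compound 3 are both reported only as limits in this assay, so the step between them cannot be read. The compounds shown leave open where the actual half-maximal cytotoxic concentration of each lies.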